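A few compounds are considered here, and "the series" means these few. Any claim that something is new, unique, unknown or untested is made for them only; others in the source may bear on it.

Measured so far in a functional assay on the whole organism with Mus musculus as the target; a higher number here means that more compound is needed for the effect, a lower number that less compound is needed:

Compound 1 `CCCS(=O)(=O)N1CCN(C(=O)CC)CC1`: 1 mg/kg
Compound 2 `CCCS(=O)(=O)N1CCN(C(C)=O)CC1`: 0.1 mg/kg
Compound 3 `CC(=O)N1CCN(S(=O)(=O)c2ccc(F)cc2)C1`: 1 mg/kg

Compound 3 stands level with compound 1 at the digits given, and compound 2 sits furthest from it. Within the core of compound 1 one step is available: a 10-fold higher number from compound 2 to compound 1 (1.00 log units; beyond the scatter), which accompanies the change (methyl in place of hydrogen on a saturated chain carbon bound to a carbonyl carbon). The difference between the core of compound 2 and the core of compound 3 is not broken down here.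

Compound 4 `CCC(=O)N1CCN(S(=O)(=O)c2ccc(F)cc2)C1` is not yet measured. It differs from compound 3 by methyl in place of hydrogen on a saturated chain carbon bound to a carbonyl carbon, the same change as between compound 2 and compound 1, at the same place. Among the compounds with values here, a step of a 10-fold higher number from compound 3 to compound 4 (1.00 log units; beyond the scatter) is expected for compound 4, because a 10-fold higher number from compound 2 to compound 1 (1.00 log units; beyond the scatter) is the only precedent for this change. Compound 4 is accordingly estimated at 10 mg/kg, expected to lie between 2 mg/kg and 30 mg/kg.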

Compound 4, minimum effective dose: 1 mg/kg
For compound 4 the middle estimate is 10-fold (1.00 log units) above the measured one; the whole stated range lies above it.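

In this assay, methyl in place of hydrogen on a saturated chain carbon bound to a carbonyl carbon gives no change at the digits printed from compound 3 to compound 4 (within the scatter). Within the data shown here, the change therefore does not carry over with one size between the two cores: the same change on two cores in this assay, a 10-fold higher number (1.00 log units; beyond the scatter) from compound 2 to compound 1 and no change at the digits printed (within the scatter) from compound 3 to compound 4, 10-fold (1.00 log units) apart, beyond the scatter of two such steps The step seen on the core of compound 2 cannot be used as a fixed increment, but the data do not show which feature of the cores sets the difference, and each core offers only a single pair.

Going by these compounds, the cores differ in more than one place, and which difference matters remains open. Also open, on these data alone, is how a longer chain such as butanoyl, or an amine on that chain, would behave on each core.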